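From Heptyl to Cyclopentyl on the Shared Core

This account rests on a few compounds, and the source may have more. Where it says the series, first, only, none or still open, it means among the compounds named here.

In a functional assay on A2780 cells (Homo sapiens) for antiproliferative activity, read by MTT assay, with a stated time of 72 h (on this read-out lower numbers stand for stronger inhibition and higher numbers for weaker inhibition), compound 1 (`CC(C)NC(=N)NC(=N)Nc1ccc(F)c(F)c1`) gives 26000 nM, while compound 2 (`CCCCCCCNC(=N)NC(=N)Nc1ccc(F)c(F)c1`) gives 1500 nM. Compound 2 thus holds the lower of the two numbers and stands as the stronger inhibitor of the pair. The next structure, compound 3 (`N=C(NC(=N)NC1CCCC1)Nc1ccc(F)c(F)c1`), has cyclopentyl in place of heptyl on an amine nitrogen. Among the measured compounds shown here, only one measured step bears on this change: a 17-fold lower number from compound 1 to compound 2 (1.24 log units; beyond the scatter), a large step beyond the scatter, with heptyl in place of isopropyl on an amine nitrogen. Neither measured compound carries a ring at this place, so that step offers only a rough guide. Losing the heptyl is expected to give back much of that gain, though probably not all of it. The expected change is a 6.7-fold higher number from compound 2 to compound 3 (0.82 log units; beyond the scatter), towards weaker inhibition and beyond the scatter. For compound 3 the estimated value is 10000 nM, within an expected range of 4000 nM to 28000 nM.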

Compound 3, half-maximal inhibitory concentration: 9300 nM
Compound 3: middle estimate off by 1.1-fold (0.03 log units), on the high side, and the stated range covers the measured number.
By their numbers in this assay, from the lowest: compound 2; then compound 3; then compound 1.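

In this assay, among the compounds shown here, cyclopentyl gives the first reading of a ring on this amine nitrogen, and it lands between the two open groups. Against the isopropyl compound the change is a 2.8-fold lower number from compound 1 to compound 3 (0.45 log units; beyond the scatter), so the ring keeps part of the gain seen with heptyl, while the change against the heptyl compound is a 6.2-fold higher number from compound 2 to compound 3 (0.79 log units; beyond the scatter), so it does not reach the level of that chain. No measurement on hand accounts for the difference between the ring and the chain at this nitrogen.

The three compounds cannot separate the effect of the ring itself from that of the size of the group, and an open pentyl chain or a cyclohexyl ring would bear directly on this. As far as these compounds go, it also remains open whether a chain longer than heptyl, or one ending in an amine, would lower the number further on the shared core.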